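The compounds below may be only part of what the source reports. "The series", "measured", "known", "first", "only" and "open" are said of these compounds alone.

Measured so far in a functional assay on DU-145 cells (Homo sapiens) for cytotoxicity, read by MTT assay, with a stated time of 48 h; a higher number here means a weaker inhibitor, a lower number a stronger inhibitor:
compound 1 `COc1ccc(/C=C/C(=O)/C=C/c2cc3ccccc3nc2Cl)cc1`: > 10000 nM
compound 2 `COc1ccc(/C=C/C(=O)/C=C/c2cc3ccccc3nc2Cl)c(OC)c1`: > 10000 nM
compound 3 `COc1cc(OC)c(OC)cc1/C=C/C(=O)/C=C/c1cc2ccccc2nc1Cl`: 3990 nM

Compound 1 gives > 10000 nM, which is a limit and not a number. Compound 2 gives > 10000 nM, which is also a limit. Compound 1 therefore stands at the limit of > 10000 nM in this assay, at which 2 of the 3 values shown sit. Only compound 3 gives a number, 3990 nM.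

Compound 4 `COc1ccc(/C=C/C(=O)/C=C/c2cc3ccccc3nc2Oc2ccccc2)cc1` differs from compound 1 by phenoxy in place of chloro on an aromatic carbon, next to the ring nitrogen: phenoxy in place of chloro on an aromatic carbon. Among the measured compounds shown here, no measured step touches this place. Both measured steps put methoxy in place of hydrogen on an aromatic carbon, so they bear on the change only indirectly. The first, a step that the two limits leave unreadable from compound 1 to compound 2, gives no size. The second, an at least 2.5-fold lower number from compound 2 to compound 3 (0.39 log units; beyond the scatter), shows that a single replacement on this series can bring a readable number in this assay. A modest move towards a lower number is therefore expected, though compound 4 may well stay at the limit. The estimated step is an at least 1.6-fold lower number from compound 1 to compound 4 (0.22 log units; that floor lies within the scatter). Compound 4 is expected at 6000 nM, within an estimated range of 1500 nM to 15000 nM.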

Compound 4, half-maximal inhibitory concentration: > 10000 nM
Compound 4: no number, only a limit; the forecaster's own chance of this, stated with the estimate: 40%; at least 1.6-fold (0.22 log units) between middle value and limit.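

In this assay, among the compounds shown here, compound 4 gives > 10000 nM, a limit and not a number, and compound 1 also sits at a limit, so no step between the two can be read. The compounds shown leave open whether phenoxy in place of chloro changes the number at all.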